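Carboxymethoxy added to the methoxyphenyl amide of compound 2

This account rests on a few compounds, and the source may have more. Where it says the series, first, only, none or still open, it means among the compounds named here.

Compound 1 `Cc1ccc(C(=O)Nc2ncc(Cc3cccc(C(F)(F)F)c3)s2)cc1C` in an assay on microsomes for inhibition of acyl-CoA desaturase 1 (Mus musculus), with a stated time of 60 min (a higher number here means a weaker inhibitor, a lower number a stronger inhibitor), gives 8220 nM. Compound 2 `COc1ccc(C(=O)Nc2ncc(Cc3cccc(C(F)(F)F)c3)s2)cc1` has no number in this assay: compound 2 gives "not determined" (no result reported), so its standing among the shown values cannot be placed. Compound 3 `COc1ccc(C(=O)Nc2ncc(Cc3cccc(C(F)(F)F)c3)s2)cc1OCC(=O)O` arises from compound 2 by carboxymethoxy in place of hydrogen on an aromatic carbon. For the measured compounds named here, no step between measured compounds exists, so no direction for this change can be read from it; a step in this assay of modest size, in either direction, or none beyond the scatter, is expected. For compound 3 the estimated result in this assay is 10000 nM, with a range from 2000 nM to 50000 nM.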

Compound 3, half-maximal inhibitory concentration: > 9990 nM
Compound 3: a limit, no number; the forecaster's own chance of this, stated with the estimate: 30%; the middle value is on the limit's open side.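

No step can be read between compound 2, which has no number, and compound 3, whose result is only a limit. The compounds shown leave open how carboxymethoxy in place of hydrogen changes inhibition.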